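This account rests on a few compounds, and the source may have more. Where it says the series, first, only, none or still open, it means among the compounds named here.

Measured compounds:
compound 1 `CC/C=C/C(CC)CC(C)CC1(CC)C=C(CC)C(C(=O)O)OO1`, 0.055 ug/mL
compound 2 `CC/C=C/C(CC)CC(C)Cc1cc(CC)c(CC(=O)O)o1`, > 20 ug/mL

In a functional assay on P388 cells (Mus musculus) for cytotoxicity (a lower number here means a stronger inhibitor, a higher number a weaker inhibitor), compound 1 gives 0.055 ug/mL. For compound 2 this assay gives > 20 ug/mL, which is a limit, not a number; compound 2 sits at the limit of > 20 ug/mL in this assay, at which 1 of the 2 values shown sits. Within the data shown here, no step between these two is counted, so only the two readings themselves can be set side by side.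

Compound 3 `CCCC(CC)CC(C)Cc1cc(CC)c(CC(=O)O)o1` is not yet measured. It differs from compound 2 by propyl in place of but-1-en-1-yl on a saturated chain carbon bound to two saturated chain carbons; the core of compound 2 and the rest of its chain are kept.

Since compound 2 stands at the limit of > 20 ug/mL in this assay, at which 1 of the 2 values shown sits, the step from compound 2 to compound 3 is expected to be a step that the limit leaves unreadable from compound 2 to compound 3, that is, no move beyond the scatter in either direction, and most likely another limit. Compound 3 is accordingly expected to give about 30 ug/mL in this assay, within the range 15 ug/mL to 100 ug/mL.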

Compound 3, half-maximal inhibitory concentration: > 20 ug/mL
Compound 3 was reported as a limit; the forecaster's own chance of this, stated with the estimate: 80%; the middle value lies beyond the limit too.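

In this assay compound 2 and compound 3 both stand as limits, so no step between them can be read: the limit of > 20 ug/mL in this assay, at which 2 of the 3 values shown sit.

The compounds shown leave open what actual reading compound 2 and compound 3 would give, and whether propyl in place of but-1-en-1-yl changes that reading at all.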